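Adding a linking carbon to the imidazole substituent

This account rests on a few compounds, and the source may have more. Where it says the series, first, only, none or still open, it means among the compounds named here.

Of the compounds shown here, three built on one shared core have been tested in an in vitro functional assay on cells for agonist activity at Bombesin receptor subtype-3 (Mus musculus), read by luminescence and calcium flux; on this read-out higher numbers stand for an effect only at larger amounts of compound and lower numbers for an effect already at smaller amounts. Compound 2 `O=C(O)c1ccccc1-c1ccc(CCc2ncc(CC3CCCCCC3)[nH]2)cc1` gives 5.7 nM, compound 1 `CCCCc1cnc(C(CCCO)Cc2ccc(-c3ccccc3C(=O)O)cc2)[nH]1` gives 238 nM, and compound 3 `O=C(O)c1ccccc1-c1ccc(CCc2ncc(-c3ccccc3)[nH]2)cc1` gives 872 nM. Compound 3 therefore stands highest of the three, with compound 1 nearest and compound 2 furthest away. Within the data shown here, the only single-point comparison available is a 150-fold higher number from compound 2 to compound 3 (2.18 log units; beyond the scatter), so swapping a cycloheptylmethyl group for a directly attached phenyl ring cost a great deal of activity.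

Compound 4 `Cc1ccc(Cc2cnc(CCc3ccc(-c4ccccc4C(=O)O)cc3)[nH]2)cc1` reverses part of that move: 4-methylbenzyl in place of phenyl on an aromatic carbon. The entering group, like the cycloheptylmethyl of compound 2, is joined to the core through one extra carbon, which the phenyl of compound 3 lacks. Because the step of a 150-fold higher number from compound 2 to compound 3 (2.18 log units; beyond the scatter) was so large, compound 4 is expected to move back toward compound 2, giving a step of about a 29-fold lower number from compound 3 to compound 4 (1.46 log units; beyond the scatter) in this assay. Compound 4 is accordingly estimated at 30 nM, within a range of 6 nM to 180 nM.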

Compound 4, half-maximal effective concentration: 162 nM
Beside the measured number, compound 4's estimate is 5.4-fold (0.73 log units) below it; low and high end bracket the measured number.
By their numbers in this assay, from the lowest: compound 2; then compounds 4 and 1 (each within the scatter of the next); then compound 3.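

Measured in this assay the 4-methylbenzyl group gives a 5.4-fold lower number from compound 3 to compound 4 (0.73 log units; beyond the scatter) and so recovers only part of the activity lost with the directly attached phenyl. A linking carbon alone does not restore the full activity at this position, since 4-methylphenyl in place of cycloheptyl on that carbon gives a 28-fold higher number from compound 2 to compound 4 (1.45 log units; beyond the scatter) and this step remains large. Nothing measured here gives a reason for either step.

The compounds shown leave open how much of the gain belongs to the linking carbon and how much to the methyl group, a split that a plain benzyl group at this position would help to settle. Also open, on these data alone, is whether a cyclohexylmethyl group on the same aromatic carbon would keep the low number seen with cycloheptylmethyl.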